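The source may hold more compounds than are shown below. What is called first, only, known or untested is meant among the compounds shown, and "the series" means these compounds.

Measured in a functional assay on HCT-116 cells (Homo sapiens) for cytotoxicity, read by MTT assay, with a stated time of 48 h; a lower number here means a stronger inhibitor, a higher number a weaker inhibitor:
compound 1 `CCN(CC)c1ccc2cc(C(=O)c3ccc(N4CCN(C(=O)CN5CCN(C(=O)CCl)CC5)CC4)cc3)oc2c1`: for compound 1 only a limit of the assay is known, > 40000 nM.
compound 2 `CCN(CC)c1ccc2cc(C(=O)c3ccc(N4CCN(C(=O)CN5CCN(S(=O)(=O)C6CC6)CC5)CC4)cc3)oc2c1`: for compound 2 only a limit of the assay is known, > 40000 nM.
compound 3 `CCN(CC)c1ccc2cc(C(=O)c3ccc(N4CCN(C(=O)CN5CCN(S(=O)(=O)c6ccc(F)cc6)CC5)CC4)cc3)oc2c1`: for compound 3 only a limit of the assay is known, > 40000 nM.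

Compound 2 thus stands at the ceiling of this assay, together with every other value shown (the limit of > 40000 nM in this assay, at which 3 of the 3 values shown sit). The three measured steps, a step that the two limits leave unreadable from compound 1 to compound 2, a step that the two limits leave unreadable from compound 1 to compound 3 and a step that the two limits leave unreadable from compound 2 to compound 3, change the group on the same ring nitrogen and each is hidden by the limit on both sides, so their size is not readable.

Compound 4 `CCN(CC)c1ccc2cc(C(=O)c3ccc(N4CCN(C(=O)CN5CCN(CC(C)=O)CC5)CC4)cc3)oc2c1` differs from compound 2 by 2-oxopropyl in place of cyclopropylsulfonyl on an amine nitrogen in a ring. The change to the same ring nitrogen in the measured steps gave nothing readable, so for compound 4 no step beyond the scatter is expected in this assay and the expected step is a step that the limit leaves unreadable from compound 2 to compound 4. Compound 4 is estimated at 60000 nM, in the range 20000 nM to 200000 nM, most likely again only as a limit.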

Compound 4, half-maximal inhibitory concentration: 24000 nM
Estimate against measurement, compound 4: 2.5-fold (0.40 log units) above, within the range that was stated.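

In this assay compound 4 is the only compound shown with a number rather than a limit, so this ring nitrogen can carry a group that brings the value under the ceiling: the limit of > 40000 nM in this assay, at which 3 of the 4 values shown sit. Each comparison gives only a floor (an at least 1.6-fold lower number from compound 2 to compound 4 (0.22 log units; that floor lies within the scatter)) (an at least 1.6-fold lower number from compound 3 to compound 4 (0.22 log units; that floor lies within the scatter)) (an at least 1.6-fold lower number from compound 1 to compound 4 (0.22 log units; that floor lies within the scatter)), and all three floors lie within the scatter. A real gain from 2-oxopropyl is therefore not established.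

The compounds shown leave open whether the carbonyl of 2-oxopropyl is needed, which a plain propyl chain on this nitrogen would test. They also leave open whether a longer chain ending in an amine or a carboxylic acid would move the number further.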